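Swapping the Amide Aryl: Methoxyphenyl Out, Bromophenyl In

This account rests on a few compounds, and the source may have more. Where it says the series, first, only, none or still open, it means among the compounds named here.

Three amides on one shared core have been measured in a functional assay on GTL 16 cells for antiproliferative activity against GTL 16 cell line (Homo sapiens), read by CCK-8 assay, with a stated time of 72 h; a higher number here means a weaker inhibitor, a lower number a stronger inhibitor. Compound 1 `O=C(Nc1cccc(-c2oc3cc(-c4ccc(F)cc4)ccc3c(=O)c2O)c1)c1ccccc1F` gives 17400 nM, compound 2 `Cc1ccc(C(=O)Nc2cccc(-c3oc4cc(-c5ccc(F)cc5)ccc4c(=O)c3O)c2)cc1` gives 12900 nM, and compound 3 `COc1ccccc1C(=O)Nc1cccc(-c2oc3cc(-c4ccc(F)cc4)ccc3c(=O)c2O)c1` gives 6370 nM. Compound 3 thus gives the lowest number of the three: a 2.0-fold lower number from compound 2 to compound 3 (0.31 log units; beyond the scatter) and a 2.7-fold lower number from compound 1 to compound 3 (0.44 log units; beyond the scatter) both lie beyond the scatter, whereas a 1.3-fold lower number from compound 1 to compound 2 (0.13 log units; within the scatter) stays within it. The change now in view is 4-bromophenyl in place of 2-methoxyphenyl on a carbonyl carbon, which yields compound 4 `O=C(Nc1cccc(-c2oc3cc(-c4ccc(F)cc4)ccc3c(=O)c2O)c1)c1ccc(Br)cc1`. The step bearing most closely on it is a 2.0-fold lower number from compound 2 to compound 3 (0.31 log units; beyond the scatter), which links a 4-methylphenyl with the 2-methoxyphenyl that now leaves; the step of a 2.7-fold lower number from compound 1 to compound 3 (0.44 log units; beyond the scatter) points the same way. Both show the 2-methoxyphenyl as the most favourable of the three groups tried, so removing it is expected to push the number back up, and a modest upward step is expected, a 1.9-fold higher number from compound 3 to compound 4 (0.28 log units; within the scatter). Compound 4 is accordingly estimated at 12000 nM, with a range from 5000 nM to 30000 nM.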

Compound 4, half-maximal inhibitory concentration: 25400 nM
Beside the measured number, compound 4's estimate is 2.1-fold (0.33 log units) below it; the measured number falls inside the stated range.
By their numbers in this assay, from the lowest: compound 3; then compounds 2, 1 and 4 (each within the scatter of the next).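

In this assay, the 2-methoxyphenyl on the carbonyl carbon now stands out against a third comparison: 4-bromophenyl in its place gives a 4.0-fold higher number from compound 3 to compound 4 (0.60 log units; beyond the scatter), the largest step yet seen at this position, and compound 3 is the strongest of the four. The 4-bromophenyl does not separate from the other two groups, as a 2.0-fold higher number from compound 2 to compound 4 (0.29 log units; within the scatter) and a 1.5-fold higher number from compound 1 to compound 4 (0.16 log units; within the scatter) both stay within the scatter. Nothing available accounts for the standing of the 2-methoxyphenyl.

The compounds shown leave open whether the lower number of compound 3 follows the methoxy group itself or its place on the ring, a question that 4-methoxyphenyl and 2-bromophenyl amides would address. They also leave open how larger 2-alkoxyphenyl groups, such as 2-ethoxyphenyl, or a 2-aminophenyl would fare at this position.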